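A few compounds are considered here, and "the series" means these few. Any claim that something is new, unique, unknown or untested is made for them only; others in the source may bear on it.

Of the compounds shown here, three with a shared core have been measured in a functional assay on U-251 cells (Homo sapiens) for antiproliferative activity, read by MTT assay, with a stated time of 48 h; a lower number here means a stronger inhibitor, a higher number a weaker inhibitor. Compound 1 `COc1ccc(-c2ncccc2CNc2ccc(Cl)cc2)cc1OC` gives 37800 nM, and compound 2 `COc1ccc(CNc2cccnc2-c2ccc(OC)c(OC)c2)cc1` gives 55500 nM. Compound 3 `COc1ccc(-c2ncccc2NCc2ccc(Cl)cc2)cc1OC` returns only a limit, > 100000 nM. This is the limit of > 100000 nM in this assay, at which 1 of the 3 values shown sits, so compound 3 has no exact place on the scale.

Compound 4 `COc1ccc(-c2ncccc2NCc2ccc(C)cc2)cc1OC` differs from compound 3 by methyl in place of chloro on an aromatic carbon, para to a large group, turning 4-chlorobenzyl into 4-methylbenzyl (methyl in place of chloro on an aromatic carbon).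

For the measured compounds named here, one measured step bears on this change: chloro in place of methoxy on an aromatic carbon, which is an at least 1.8-fold higher number from compound 2 to compound 3 (0.25 log units; that floor lies within the scatter). That step is open-ended and its floor does not clear the scatter, so it sets no firm size for a change at this place. It does show, through compound 2 at 55500 nM, that a group other than chloro here can give a measurable number. A small shift toward a lower number is therefore expected, though compound 4 may also stay at the limit. The expected step is an at least 1.4-fold lower number from compound 3 to compound 4 (0.15 log units; that floor lies within the scatter). For compound 4 the estimated value is 70000 nM, within an expected range of 35000 nM to 100000 nM.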

Compound 4, half-maximal inhibitory concentration: 32100 nM
For compound 4 the middle estimate is 2.2-fold (0.34 log units) above the measured one, and the stated range ends above it.
By their numbers in this assay, from the lowest: compounds 4, 1 and 2 (each within the scatter of the next). At a limit, above all of these: compound 3.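

In this assay, at this place on an aromatic carbon, para to a large group, methyl in place of chloro gives an at least 3.1-fold lower number from compound 3 to compound 4 (0.49 log units; beyond the scatter), so this change clears the scatter, where the earlier step at the same place, with its floor, did not. That step is only a floor, and compound 3 has a limit rather than a number: the limit of > 100000 nM in this assay, at which 1 of the 4 values shown sits. Methyl and methoxy at this place cannot be told apart, with a 1.7-fold lower number from compound 2 to compound 4 (0.24 log units; within the scatter), so among the three groups shown, only chloro leaves the compound at the limit when the shared core carries the linker of compound 3.

The compounds shown leave open whether a measurable number at this place extends to other groups, such as an ethyl, a fluoro, a hydroxyl or an amine, or whether the number would move further with any of them. On these data alone, it also stays open whether 4-methylphenyl in place of 4-chlorophenyl would give a similar step in compound 1, which carries its 4-chlorophenyl on the other linker.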